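Swapping cyclohexyl for benzimidazolyl on the thioether arm

The source may report more compounds than this note shows. Statements on the series, on what has been measured and on what is new or still open speak of the compounds shown alone.

Measured compounds:
compound 1 `Cc1cc(Nc2cc(-c3ccccc3)[nH]n2)n2nc(SCC3CCCCC3)nc2n1`: > 50000 nM
compound 2 `CCCCCc1c(C)nc2nc(SCc3ccc(Cl)cc3)nn2c1Nc1cc(-c2ccccc2)[nH]n1`: > 50000 nM
compound 3 `Cc1cc(Nc2ccn(Cc3ccc(F)cc3)n2)n2nc(SCc3ccc(Br)cc3)nc2n1`: 19400 nM

In a functional assay on PC-9 cells (Homo sapiens) for inhibition, read by MTT assay, with a stated time of 72 h (a lower number here means a stronger inhibitor, a higher number a weaker inhibitor), compound 1 gives > 50000 nM, which is a limit of the assay and not a number. Compound 2 also stops at a limit in this assay, at > 50000 nM. Compound 3 is the only one of the three with a number, giving 19400 nM in this assay. So compound 1 sits at the weak end of what is known here, together with compound 2, as noted by the limit of > 50000 nM in this assay, at which 2 of the 3 values shown sit.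

Compound 4 `Cc1cc(Nc2cc(-c3ccccc3)[nH]n2)n2nc(SCc3nc4ccccc4[nH]3)nc2n1` is not yet measured. It keeps the core of compound 1 and changes one group on the chain bound to the sulfur: 1H-benzimidazol-2-yl in place of cyclohexyl on a saturated chain carbon bound to a sulfur.

For the measured compounds named here, since compound 1 offers only a limit, the step to compound 4 can only be an expectation, and a modest one at most; a move beyond the scatter in either direction would not be surprising, but no measured pair supports it. The estimated change is an at least 1.4-fold lower number from compound 1 to compound 4 (0.15 log units; that floor lies within the scatter). Compound 4 is expected to give 35000 nM in this assay, within 8000 nM to 60000 nM.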

Compound 4, half-maximal inhibitory concentration: 4840 nM
Compound 4: middle estimate off by 7.2-fold (0.86 log units), on the high side, and the stated range ends above it.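

Changing the group on the chain bound to the sulfur matters in this assay: with the shared core kept, 1H-benzimidazol-2-yl in place of cyclohexyl gives an at least 10-fold lower number from compound 1 to compound 4 (1.01 log units; beyond the scatter). For the compounds shown here, the earlier compounds could not show this, since none of them forms a pair with another that differs in one place, so this is the first single change that can be read at this position. The true size of the step stays unknown because compound 1 stands at a limit and not at a number: the limit of > 50000 nM in this assay, at which 2 of the 4 values shown sit.

The compounds shown leave open whether the step follows from the ring nitrogens or from the fused six-membered aromatic ring, which an imidazol-2-yl or an indol-2-yl on the same chain carbon would separate. They also leave open how an amine or a carboxylic acid on the benzimidazole would read here.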